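Exchanging a chlorophenyl for a dimethoxyphenyl on the anilino nitrogen

The source may hold more compounds than are shown below. What is called first, only, known or untested is meant among the compounds shown, and "the series" means these compounds.

For the measured compounds named here, in a functional assay on MCF7 cells (Homo sapiens) for cytotoxicity, read by MTT assay, with a stated time of 72 h (on this read-out lower numbers stand for stronger inhibition and higher numbers for weaker inhibition), compound 3 `FC(F)(F)c1ccc(CSc2nc(Nc3ccc(Cl)cc3)c3ccccc3n2)cc1` gives 21500 nM, the only actual number among the three measured compounds. Compound 1 `FC(F)(F)c1ccc(CSc2nc(Nc3ccccc3Cl)c3ccccc3n2)cc1` reaches only the assay limit > 50000 nM in this assay. Compound 2 `O=[N+]([O-])c1cccc(Nc2nc(SCc3ccc(C(F)(F)F)cc3)nc3ccccc23)c1` likewise sits at the limit > 50000 nM. The two measured steps that end at the 4-chlorophenyl read an at least 2.3-fold lower number from compound 1 to compound 3 (0.36 log units; beyond the scatter) and an at least 2.3-fold lower number from compound 2 to compound 3 (0.36 log units; beyond the scatter), while the remaining pair reads a step that the two limits leave unreadable from compound 1 to compound 2. Compound 4 `COc1cc(Nc2nc(SCc3ccc(C(F)(F)F)cc3)nc3ccccc23)cc(OC)c1` carries 3,5-dimethoxyphenyl in place of 4-chlorophenyl on a nitrogen on an aromatic ring. Going by the values given here, no measured step exchanges a chlorine for two methoxy groups, so the expectation rests on the two measured steps alone, which show that every departure from the 4-chlorophenyl seen so far raised the number beyond the scatter. The estimate for compound 4 is therefore 35000 nM (range 10000 nM to 120000 nM), meaning an expected step of a 1.6-fold higher number from compound 3 to compound 4 (0.21 log units; within the scatter) in this assay.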

Compound 4, half-maximal inhibitory concentration: 6990 nM
Beside the measured number, compound 4's estimate is 5.0-fold (0.70 log units) above it; measured number outside the range, below it.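

Exchanging 4-chlorophenyl for 3,5-dimethoxyphenyl on the nitrogen gives a 3.1-fold lower number from compound 3 to compound 4 (0.49 log units; beyond the scatter) in this assay, so the 4-chlorophenyl no longer holds the lowest number at this position. Compound 4 is the strongest of the four compounds, though still modest in size of step. Against the other two groups the steps read an at least 7.1-fold lower number from compound 2 to compound 4 (0.85 log units; beyond the scatter) and an at least 7.1-fold lower number from compound 1 to compound 4 (0.85 log units; beyond the scatter), and these are bounds only: the limit of > 50000 nM in this assay, at which 2 of the 4 values shown sit.

From the compounds shown here alone, whether both methoxy groups are needed stays open. So does how a single methoxy group, a hydroxyl group or an amine on that phenyl ring would read.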